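A few compounds are considered here, and "the series" means these few. Any claim that something is new, unique, unknown or untested is made for them only; others in the source may bear on it.

Measured compounds and their maximal responses:

Compound 1 `Cc1ccccc1-c1cc(C#Cc2ccc(CCC(=O)O)cc2)ccn1`: 92%
Compound 2 `O=C(O)CCc1ccc(C#Cc2ncccc2[N+](=O)[O-])cc1`: 87%
Compound 3 `O=C(O)CCc1ccc(C#Cc2cc(Cl)nc(Cl)c2)cc1`: 103%

All three compounds share a core in which an acid-bearing chain and an alkyne link lead to a six-membered ring with one nitrogen, and they differ in what sits on that ring. In an in vitro functional assay on 1321-N1 cells for agonist activity at Free fatty acid receptor 1 (Homo sapiens), read by fluorescence, spectrophotometry and calcium flux (on this read-out lower numbers stand for smaller maximal responses and higher numbers for larger maximal responses), compound 1 gives 92%. Compound 2 gives 87%, a number that lies within the usual scatter of compound 1, so the two cannot be told apart on this read-out. Compound 3 gives 103%, a number higher than that of compound 1 by more than the scatter, so compound 1 stands second highest of the three.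

Compound 4 `O=C(O)CCc1ccc(C#Cc2ccnc(Oc3ccccc3)c2)cc1` has not yet been measured in this assay. It comes from compound 1 by one change: phenoxy in place of 2-methylphenyl on an aromatic carbon. The group that enters carries one hydrogen-bond acceptor where the group that leaves carried none, and it sits next to the ring nitrogen.

Going by the values given here, no two measured compounds differ in exactly one place, so no measured step can guide the size of this one. Since every compound shown reaches a large maximal response, the step from compound 1 to compound 4 is expected to stay within the scatter, with no clear direction: a number 2 percentage points lower from compound 1 to compound 4 (within the scatter). Compound 4 is therefore estimated to give 90%, expected between 70% and 108%.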

Compound 4, largest response reached (reported as efficacy), in percent of the reference or control that the assay uses: 94%
The estimate for compound 4 lay 4 percentage points below the measured number, and the stated range covers the measured number.
By their numbers in this assay, from the lowest: compounds 2, 1, 4 and 3 (each within the scatter of the next, the first and the last beyond it).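

Replacing 2-methylphenyl with phenoxy on the aromatic carbon next to the ring nitrogen gives, in this assay, a number 2 percentage points higher from compound 1 to compound 4 (within the scatter), so the two compounds cannot be told apart on this read-out. This is the first comparison among the compounds shown in which only one place differs, and it shows that a large maximal response is kept at this position when the entering group carries a hydrogen-bond acceptor and the leaving group carries none. No measurement here explains why these two groups match on this read-out.

As far as these compounds go, both groups contain a six-membered aromatic ring of carbon only and have the same count of heavy atoms, so it remains open whether a large maximal response would survive at this position with a group lacking such a ring, such as an amine or a longer alkyl chain. The largest response also says nothing about how low a concentration each compound needs to reach it, so compound 1 and compound 4 could still differ in that respect.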